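A few compounds are considered here, and "the series" means these few. Any claim that something is new, unique, unknown or untested is made for them only; others in the source may bear on it.

For the measured compounds named here, compound 3 `COc1ccc(COC(=O)[C@H](CC(=O)OC2CCC2)NC(=O)OC(C)(C)C)cc1` stands at the high end of the three compounds measured so far in a functional assay on IMR-32 cells for inhibition of Voltage-dependent N-type calcium channel subunit alpha-1B (Homo sapiens), read by calcium flux (on this read-out lower numbers stand for stronger inhibition and higher numbers for weaker inhibition), where compound 3 gives 15000 nM. Compound 1 `COc1ccc(CN(C)C(=O)[C@H](COCC2CCCCC2)NC(=O)OC(C)(C)C)cc1` gives 1800 nM in this assay, and compound 2 `COc1ccc(CNC(=O)[C@H](CSCC2CCCC2)NC(=O)OC(C)(C)C)cc1` gives 630 nM; the gaps from compound 3 to each of them lie beyond the scatter, so compound 3 is the weakest inhibitor of the three. The account follows the step from compound 3 to compound 4 `COc1ccc(COC(=O)[C@H](CC(=O)OC2CCCCC2)NC(=O)OC(C)(C)C)cc1`, which differs from it in a single place: cyclohexyl in place of cyclobutyl on an oxygen next to a carbonyl group. Going by the values given here, no step between two measured compounds that differ only in this way has been recorded, so the expectation rests on the structures alone. Compounds 1 and 2, which both show lower numbers, differ from compound 3 in several places at once and therefore offer no isolated reading of this one change. A modest move toward a lower number is expected, with the step estimated as a 2.1-fold lower number from compound 3 to compound 4 (0.33 log units; beyond the scatter), which may or may not clear the scatter. Compound 4 is accordingly estimated at 7000 nM in this assay, with an expected range of 2500 nM to 20000 nM.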

Compound 4, half-maximal inhibitory concentration: 2300 nM
The estimate for compound 4 lay 3.0-fold (0.48 log units) above the measured number; the measured number lies below the stated range.
By their numbers in this assay, from the lowest: compound 2; then compounds 1 and 4 (each within the scatter of the next); then compound 3.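

The change of cyclobutyl to cyclohexyl on an oxygen next to a carbonyl group gives a 6.5-fold lower number from compound 3 to compound 4 (0.81 log units; beyond the scatter) in this assay, an isolated reading of this change that compound 1 and compound 2 could not supply, as each differs from compound 3 in several places at once. It shows that inhibition at this position responds to the ring carried there: within this pair, the six-membered ring of carbon only goes with the lower number, although a single pair of compounds establishes no trend across ring sizes. The data shown offer no measurement that would explain this step.

As far as these compounds go, it remains open whether a straight hexyl chain or a ring-bearing amine on this same oxygen would read closer to compound 3 or to compound 4. It is also open whether the step from cyclobutyl to cyclohexyl would hold on a different core, since the one pair shown tests the change only on the core shared by compound 3 and compound 4.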